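The compounds below may be only part of what the source reports. "The series", "measured", "known", "first", "only" and "open" are said of these compounds alone.

Compound 2 `CCN(CC)CCNc1cc(C)c2cc(NC(=O)c3ccc(Cl)c(Cl)c3)ccc2n1` is the compound from which this account departs. In a functional assay on MCF7 cells (Homo sapiens) for antiproliferative activity, read by MTT assay, with a stated time of 72 h (on this read-out lower numbers stand for stronger inhibition and higher numbers for weaker inhibition), compound 2 gives 1420 nM, the lowest of the three numbers recorded so far. Its nearest neighbour is compound 1 `Cc1cc(NCCN(C)C)nc2ccc(NC(=O)c3ccc(Cl)c(Cl)c3)cc12`, which in this assay gives 2550 nM; the step of a 1.8-fold lower number from compound 1 to compound 2 (0.25 log units; within the scatter) separates the two. Compound 3 `CCN1CCN(c2cc(C)c3cc(NC(=O)c4ccccc4C)ccc3n2)CC1` differs from compound 2 in several places. In this assay compound 3 gives 10900 nM, the highest of the three.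

Compound 4 `Cc1cc(NCCN2CCN(C)CC2)nc2ccc(NC(=O)c3ccc(Cl)c(Cl)c3)cc12` has not yet been measured. It differs from compound 2 in one place: 4-methylpiperazin-1-yl in place of diethylamino on a saturated chain carbon, two bonds along the chain from a nitrogen on an aromatic ring. Within the data shown here, the only measured step at the same place is a 1.8-fold lower number from compound 1 to compound 2 (0.25 log units; within the scatter), an exchange of dimethylamino for diethylamino that left the number within the scatter. Among the measured compounds shown here, the present change is larger, replacing diethylamino with 4-methylpiperazin-1-yl, a group carrying one six-membered non-aromatic ring, and no measured pair shows what such a ring does here. The numbers therefore give no basis for expecting a move in either direction, and the expected step of a 1.4-fold higher number from compound 2 to compound 4 (0.15 log units; within the scatter) is small, with wide uncertainty around it. Compound 4 is estimated at 2000 nM in this assay, with a range from 700 nM to 6000 nM.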

Compound 4, half-maximal inhibitory concentration in the MCF7 assay: 1700 nM
The estimate for compound 4 lay 1.2-fold (0.07 log units) above the measured number; the measured number falls inside the stated range.
By their numbers in the MCF7 assay, from the lowest: compounds 2, 4 and 1 (each within the scatter of the next); then compound 3.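

In the MCF7 assay the first ring at this chain end gives a 1.2-fold higher number from compound 2 to compound 4 (0.08 log units; within the scatter) and a 1.5-fold lower number from compound 1 to compound 4 (0.18 log units; within the scatter) and so stays within the scatter of both open-chain amines, which the dimethylamino to diethylamino step alone could not show. Compounds 1, 2 and 4 therefore cannot be told apart in this assay, even though 4-methylpiperazin-1-yl brings one six-membered non-aromatic ring and a second nitrogen to this position. In a physicochemical assay for solubility (a lower number here means a less soluble compound, a higher number a more soluble compound), compound 2 gives 95.2 ug/mL and compound 4 gives 106 ug/mL for a step of a 1.1-fold higher number from compound 2 to compound 4 (0.05 log units; within the scatter) and so the exchange leaves solubility within the scatter too, though no measurement shown accounts for either result.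

The compounds shown leave open whether a morpholine or a carboxylic acid at the chain end, or a longer chain carrying the same amines, would move the number in the MCF7 assay beyond the scatter. They also leave open whether this insensitivity to the terminal amine would persist if the dichlorophenyl amide shared by compounds 1, 2 and 4 were replaced by another amide.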